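The source may report more compounds than this note shows. Statements on the series, on what has been measured and on what is new or still open speak of the compounds shown alone.

Of the compounds shown here, three have been tested in an ADME assay on HFL1 cells (Homo sapiens) for antiproliferative activity, read by crystal violet staining, with a stated time of 96 h; on this read-out lower numbers stand for an effect already at smaller amounts and higher numbers for an effect only at larger amounts of compound. Compound 1 `O[C@@H]1[C@@H](O)[C@H](Oc2ccc(S)c3ccccc23)OC[C@H]1O` gives 70 uM in this assay. Compound 2 `O[C@@H]1[C@@H](O)[C@H](Oc2cc3ccccc3cc2S)OC[C@H]1O` gives 60 uM in this assay, and compound 3 `Oc1cccc2c(S[C@@H]3OC[C@@H](O)[C@H](O)[C@H]3O)cccc12` gives 135 uM. Among these three numbers, compound 1 stands second highest; the number for compound 2 lies closest to it and that for compound 3 lies furthest from it, yet both gaps fall within the scatter of repeated measurements, so no ranking of the three can be read from them. Compound 4 `CCCSc1ccc(O[C@@H]2OC[C@@H](O)[C@H](O)[C@H]2O)c2ccccc12` has not yet been tested in this assay. It differs from compound 1 by a single change, (propyl in place of hydrogen on a sulfur), that is, propyl in place of hydrogen on a sulfur. Going by the values given here, no pair of measured compounds differs by a change of this kind, so there is no measured step to lean on. The step from compound 1 to compound 4 is expected to be small, a 1.4-fold lower number from compound 1 to compound 4 (0.15 log units; within the scatter), and not clearly beyond the scatter. Compound 4 is therefore estimated at 50 uM in this assay, with a range from 20 uM to 150 uM.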

Compound 4, concentration for half-maximal effect: 30 uM
The estimate for compound 4 lay 1.7-fold (0.22 log units) above the measured number, within the range that was stated.
By their numbers in this assay, from the lowest: compounds 4, 2, 1 and 3 (each within the scatter of the next, the first and the last beyond it).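

In this assay, the sulfur of compound 1 proves able to carry a substituent, since propyl in place of hydrogen on that sulfur gives a 2.3-fold lower number from compound 1 to compound 4 (0.37 log units; beyond the scatter) and this modest step lies beyond the scatter. The earlier compounds shown here held no pair differing in one place, so they could not show what any single change does, and they said nothing about this sulfur in particular. Nothing measured here bears on what lies behind the step.

On these data alone, whether methyl, a longer chain, an amine or a carboxylic acid in place of propyl on this sulfur would give a smaller, larger or opposite step remains open. Also open, as far as these compounds go, is whether propyl in place of hydrogen on the sulfur of compound 2 would give a step of similar size.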